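The source may hold more compounds than are shown below. What is called first, only, known or untested is meant among the compounds shown, and "the series" means these compounds.

In a functional assay on K562 cells (Homo sapiens) for cytotoxicity, read by MTT assay, with a stated time of 48 h (a lower number here means that less compound is needed, a higher number that more compound is needed for the effect), compound 1 `Cc1c(O)c(=O)ccn1CC(=O)N/N=C1\C(=O)N(CC(=O)Nc2ccc(Br)cc2)c2ccccc21` gives 1850 nM, which stands at the top of the two numbers measured, though compound 2 `Cc1c(O)c(=O)ccn1CC(=O)N/N=C1\C(=O)N(CC(=O)Nc2ccc(Cl)cc2Cl)c2ccccc21`, giving 1810 nM in this assay, lies within the scatter of it, as the step of a 1.0-fold lower number from compound 1 to compound 2 (0.01 log units; within the scatter) shows. Compound 3 `Cc1c(O)c(=O)ccn1CC(=O)N/N=C1\C(=O)N(CC(=O)Nc2cc(Cl)cc(Cl)c2)c2ccccc21` differs from compound 1 by 3,5-dichlorophenyl in place of 4-bromophenyl on an amide-type nitrogen. Among the measured compounds shown here, the only measured step at this position, a 1.0-fold lower number from compound 1 to compound 2 (0.01 log units; within the scatter), stayed within the scatter, so the expected step is a 1.0-fold lower number from compound 1 to compound 3 (0.01 log units; within the scatter), nothing beyond the scatter. Compound 3 is therefore estimated to give about 1800 nM in this assay, with a range from 900 nM to 3600 nM.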

Compound 3, half-maximal effective concentration: 1220 nM
Estimate against measurement, compound 3: 1.5-fold (0.17 log units) above, within the range that was stated.
By their numbers in this assay, from the lowest: compounds 3, 2 and 1 (each within the scatter of the next).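

The step of a 1.5-fold lower number from compound 1 to compound 3 (0.18 log units; within the scatter) and the step of a 1.5-fold lower number from compound 2 to compound 3 (0.17 log units; within the scatter) both stay within the scatter in this assay, so a second dichlorophenyl pattern on this amide-type nitrogen is now seen, and the three halogen-bearing aryl groups cannot be told apart. No measured evidence bears on the reason for these numbers. The compounds shown leave open whether an unsubstituted phenyl group would also stay within the scatter. They also leave open whether an amine or a carboxylic acid in place of the halogens would move the number beyond it.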